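Exocyclic linkage and ring swap on the metabolic stability series

The compounds below may be only part of what the source reports. "The series", "measured", "known", "first", "only" and "open" are said of these compounds alone.

Measured so far:
compound 1, `CC(C)C(/C=C1/C(=O)NC(=O)N1C)c1ccc(-c2ccc3cccc(F)c3c2)[nH]c1=O`, > 3 h
compound 2, `CC(C)C(CC1C(=O)NC(=O)N1C)c1ccc(-c2ccc3cccc(F)c3c2)[nH]c1=O`, 0.153 h

In an ADME assay on microsomes from liver (Homo sapiens) for metabolic stability (a lower number here means that the compound disappears faster, a higher number that the compound lasts longer), compound 1 reaches only a limit of the assay, > 3 h, and gives no number. Among the compounds with values here, compound 2 gives 0.153 h, the only plain number in this assay so far. The value of compound 1 is a limit, as noted for (the limit of > 3 h in this assay, at which 1 of the 2 values shown sits). Within the data shown here, the step of an at least 19-fold lower number from compound 1 to compound 2 (1.29 log units; beyond the scatter) is the single measured step and it is large.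

Compound 3, `CC(C)C(/C=C1\SC(=O)NC1=O)c1ccc(-c2ccc3cccc(F)c3c2)[nH]c1=O`, is not yet measured. Relative to compound 2 the change is a group of 8 heavy atoms (4 carbon, 1 nitrogen, 2 oxygen, 1 sulfur; one five-membered non-aromatic ring with 2 hetero atoms) in place of a group of 9 heavy atoms (5 carbon, 2 nitrogen, 2 oxygen; one five-membered non-aromatic ring with 2 hetero atoms), on a saturated chain carbon bound to an aromatic carbon and a saturated chain carbon. The group that enters carries 3 double bonds outside aromatic rings where the leaving (3-methyl-2,5-dioxoimidazolidin-4-yl)methyl carries 2, so the unsaturated exocyclic linkage of compound 1 returns, while the five-membered ring itself is altered. Among the measured compounds shown here, the measured step from compound 1 to compound 2 therefore bears on this change, but only in part; the ring swap has no measured counterpart here.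

A step toward longer half-life is expected, of roughly the size a 12-fold higher number from compound 2 to compound 3 (1.07 log units; beyond the scatter). Compound 3 is estimated at 1.8 h, within 0.5 h to 5 h.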

Compound 3, half-life: > 3 h
Compound 3: a limit, no number; the forecaster's own chance of this, stated with the estimate: 35%; at least 1.6-fold (0.22 log units) between middle value and limit.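

In this assay, the change at this saturated chain carbon gives an at least 19-fold higher number from compound 2 to compound 3 (1.29 log units; beyond the scatter), so a second ring group carrying the unsaturated exocyclic linkage now stands well apart from the saturated (3-methyl-2,5-dioxoimidazolidin-4-yl)methyl group of compound 2. Within the data shown here, the result for compound 3 is a limit of the assay and not a number, as for compound 1, and the step between these two compounds cannot be read, so their two ring groups cannot be ordered: the limit of > 3 h in this assay, at which 2 of the 3 values shown sit. Among the three compounds, the unsaturated linkage goes with the limit and the saturated linkage with the one plain number, with no compound against this, and with the sulfur-containing ring the unsaturated linkage holds as it does with the ring of compound 1.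

The compounds shown do not separate linkage from ring, since the sulfur-containing ring appears only on the unsaturated linkage and compound 2 differs from compound 3 in both. From the compounds shown here alone, how far the half-life depends on a five-membered ring at all stays open, as no simpler group such as a carboxylic acid or a primary amide appears at this position.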